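The source may hold more compounds than are shown below. What is called first, only, known or untested is meant among the compounds shown, and "the series" means these compounds.

Working notes on the chlorobenzyl pair and the next member.

Compound 1 `Nc1ncn(Cc2ccccc2Cl)c2ncnc1-2` carries one chloro on the benzyl ring. In an assay on isolated protein (adrenal medulla) for inhibition of Dopamine beta-hydroxylase (Bos taurus) (a lower number here means a stronger inhibitor, a higher number a weaker inhibitor), compound 1 gives 200 ug/mL. Compound 2 `Nc1ncn(Cc2cccc(Cl)c2)c2ncnc1-2` carries its single chloro at a different carbon of the same ring, and in this assay compound 2 gives 2 ug/mL. Compound 1 therefore stands with the highest number of the two, and the gap to compound 2 lies beyond the scatter; the position of the single chloro on the benzyl ring evidently matters a great deal for this enzyme.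

Compound 3 `Nc1ncn(Cc2ccc(Cl)cc2Cl)c2ncnc1-2` keeps the chloro of compound 1 and adds a second one: chloro in place of hydrogen on an aromatic carbon, on an aromatic carbon of a six-membered aromatic ring of carbon only. Going by the values given here, no measured pair shows the effect of adding a second chloro, so the step can only be guessed. Given that compound 1 sits at 200 ug/mL and compound 2 sits far lower, a downward step of moderate size is expected, a 4.0-fold lower number from compound 1 to compound 3 (0.60 log units; beyond the scatter), though the wide range reflects the lack of a direct precedent. For compound 3 in this assay the expected value is 50 ug/mL, within 8 ug/mL to 300 ug/mL.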

Compound 3, half-maximal inhibitory concentration: 200 ug/mL
Beside the measured number, compound 3's estimate is 4.0-fold (0.60 log units) below it, within the range that was stated.
By their numbers in this assay, from the lowest: compound 2; then compounds 1 and 3 (each within the scatter of the next).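

In this assay, going by these compounds alone, chloro in place of hydrogen on this aromatic carbon, meta to a chloro group and para to a large group, gives no change at the digits printed from compound 1 to compound 3 (within the scatter) and so provides the first single-place step. On the benzyl ring of compound 1, this carbon therefore accepts a chloro with the two numbers remaining within the scatter, and the added chlorine atom brings no gain in this assay at this position. No measurement bears on why the step reads this way.

The compounds shown leave open whether this result is specific to chloro, since a group such as methoxy, an amine or a carboxylic acid on the same carbon of compound 1 could give a quite different number. On these data alone, it also remains open whether a second chloro on the benzyl ring would be tolerated equally on compound 2, which gives 2 ug/mL in this assay and so offers a lower starting number against which any such step could be read.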